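The compounds below may be only part of what the source reports. "The series", "measured", "known", "first", "only" and "open" are said of these compounds alone.

Read-out: an ADME assay on Vero cells (Chlorocebus sabaeus) for cytotoxicity, read by flow cytometry and propidium iodide staining, with a stated time of 72 h; on this read-out lower numbers stand for stronger inhibition and higher numbers for weaker inhibition
- compound 1 `CNCCOCCn1nc(OCc2ccccc2)c2cc([N+](=O)[O-])ccc21` gives 214000 nM
- compound 2 `COc1nn(CCOCCN)c2ccc([N+](=O)[O-])cc12` gives 87200 nM
- compound 3 `COc1nn(C)c2ccc([N+](=O)[O-])cc12` gives 183000 nM

Compound 3 lies within the usual scatter of compound 1, and a modest measured step separates it from compound 2 (a 2.1-fold higher number from compound 2 to compound 3 (0.32 log units; beyond the scatter)). The change to compound 4 `CNCCOCCn1nc(OC)c2cc([N+](=O)[O-])ccc21` is (2-(methylamino)ethoxy)methyl in place of hydrogen on a saturated chain carbon bound to an aromatic nitrogen with (2-(methylamino)ethoxy)methyl in place of hydrogen on a saturated chain carbon bound to an aromatic nitrogen. Going by the values given here, only the step above bears directly on this change, as it removes a closely related chain. Among the compounds with values here, compound 1 carries the same chain but differs in a second place, so it offers no clean step. A modest move to a lower number is therefore expected in this assay on going the other way. The estimated step is a 1.8-fold lower number from compound 3 to compound 4 (0.26 log units; within the scatter) and it stays an expectation. For compound 4 the estimate is 100000 nM with an expected range from 55000 nM to 190000 nM in this read-out.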

Compound 4, half-maximal inhibitory concentration: 87600 nM
Compound 4: middle estimate off by 1.1-fold (0.06 log units), on the high side; low and high end bracket the measured number.
By their numbers in this assay, from the lowest: compounds 2 and 4 (each within the scatter of the next); then compounds 3 and 1 (each within the scatter of the next).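

In this assay the step of a 2.1-fold lower number from compound 3 to compound 4 (0.32 log units; beyond the scatter) shows that (2-(methylamino)ethoxy)methyl on a saturated chain carbon bound to an aromatic nitrogen also gives a lower number, as the chain without the methyl does. The step of a 1.0-fold higher number from compound 2 to compound 4 (0.00 log units; within the scatter) leaves methyl and hydrogen on the amine nitrogen within the scatter of each other. With this chain in place, the step of a 2.4-fold lower number from compound 1 to compound 4 (0.39 log units; beyond the scatter) shows that hydrogen in place of phenyl also gives a lower number.

Going by these compounds, whether a dimethylamine, a carboxylic acid or a longer chain here would keep the lower number remains open. No measurement shown gives a reason for any of these steps.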